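A few compounds are considered here, and "the series" means these few. Any claim that something is new, unique, unknown or untested is made for them only; others in the source may bear on it.

Measured so far:
Compound 1, `Fc1ccc(-c2noc3c2CCNCC3)cc1`, gives 38.2% in a functional assay on cells for agonist activity at 5-hydroxytryptamine receptor 7 (Homo sapiens), read by a luciferase reporter and beta-arrestin recruitment, with a stated time of 22 h; on this read-out higher numbers stand for larger maximal responses and lower numbers for smaller maximal responses.
Compound 2, `Cc1ccc(-c2noc3c2CCNCC3)cc1`, gives 40.3% in this assay.

For the measured compounds named here, compound 2 holds the higher of the two numbers recorded, yet its only neighbour, compound 1, sits within the scatter of it, so no order between the two can be claimed. Going by the values given here, the single step that can be compared, a number 2.1 percentage points higher from compound 1 to compound 2 (within the scatter), shows that exchanging one small group for another on that aromatic carbon left the maximal response essentially where it was. Compound 3, `Clc1ccc(-c2noc3c2CCNCC3)cc1`, has not yet been measured. It differs from compound 2 in one place: chloro in place of methyl on an aromatic carbon. The methyl leaves and a chloro enters, again a single heavy atom without ring, donor or acceptor. Among the compounds with values here, only that one measured step bears on this change, and it stayed within the scatter, so the step of a number 0.3 percentage points lower from compound 2 to compound 3 (within the scatter) is expected to be small and without clear direction. Compound 3 is therefore estimated at 40%, with a range from 28% to 52%.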

Compound 3, largest response reached (Emax), in percent of the reference or control that the assay uses: 47.1%
Estimate against measurement, compound 3: 7.1 percentage points below; the measured number falls inside the stated range.
By their numbers in this assay, from the lowest: compounds 1, 2 and 3 (each within the scatter of the next).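

With chloro, this carbon, para to a large group, has now carried fluoro, methyl and chloro in this assay, and both new steps stay within the usual scatter (a number 6.8 percentage points higher from compound 2 to compound 3 (within the scatter); a number 8.9 percentage points higher from compound 1 to compound 3 (within the scatter)). The earlier pair gave only one comparison, whereas all three pairs can now be read, and none of them supports an order among these groups, so on this evidence the exchange of one for another leaves the maximal response unresolved. Nothing measured here offers a reason for the small differences among the three numbers.

As far as these compounds go, it remains open whether a different kind of group on this carbon, such as an amine, a carboxylic acid or a longer chain, would move the maximal response beyond the scatter. The compounds shown also cannot tell how changes elsewhere on the shared core would behave.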